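Swapping 2-phenylphenyl for 4-(trifluoromethyl)phenyl on an amine nitrogen

This account rests on a few compounds, and the source may have more. Where it says the series, first, only, none or still open, it means among the compounds named here.

In a physicochemical assay for lipophilicity (a lower number here means a more polar compound, a higher number a more lipophilic compound), compound 1 `C=C(c1cccc2ccccc12)C1CCC2(CC1)COC(Nc1ccccc1)OO2` gives 5.59 and compound 2 `C=C(c1cccc2ccccc12)C1CCC2(CC1)COC(Nc1ccccc1-c1ccccc1)OO2` gives 7.26 on the same scale, which makes compound 2 the higher of the two. Going by the values given here, the only measured step is a number 1.67 log units higher from compound 1 to compound 2 (beyond the scatter) when phenyl takes the place of hydrogen on an aromatic carbon. Compound 3 `C=C(c1cccc2ccccc12)C1CCC2(CC1)COC(Nc1ccc(C(F)(F)F)cc1)OO2` has not yet been measured. Its change is 4-(trifluoromethyl)phenyl in place of 2-phenylphenyl on an amine nitrogen with 4-(trifluoromethyl)phenyl in place of 2-phenylphenyl on an amine nitrogen. Among the compounds with values here, this swap removes the phenyl of the measured step, so a fall is expected, but no measured step covers trifluoromethyl. Only part of the rise seen with compound 2 is therefore expected to be given back. The expected change is a number 0.76 log units lower from compound 2 to compound 3 (beyond the scatter) in this assay and should be moderate. For compound 3 the estimated value is 6.5 with an expected range from 6 to 7 in this measurement.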

Compound 3, partition coefficient: 6.51
Compound 3: the middle estimate sits 0.01 log units below what was measured; measured number inside the range.
By their numbers in this assay, from the lowest: compound 1; then compound 3; then compound 2.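

In this assay, phenyl is no longer the only group shown to move the number at this aryl group on the amine nitrogen: trifluoromethyl also raises it (a number 0.92 log units higher from compound 1 to compound 3 (beyond the scatter)). Moving from 2-phenylphenyl to 4-(trifluoromethyl)phenyl on that nitrogen gives back only part of the rise seen with phenyl (a number 0.75 log units lower from compound 2 to compound 3 (beyond the scatter)), leaving compound 3 between compound 1 and compound 2, so a second aromatic ring is not needed for a number higher than that of compound 1. Nothing available gives a reason for either step.

The compounds shown leave open whether a methoxy group or a nitrile on the same aryl group would also raise the number. On these data alone, it is also open whether an amine or a carboxylic acid there would bring the number under that of compound 1.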